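This account rests on a few compounds, and the source may have more. Where it says the series, first, only, none or still open, it means among the compounds named here.

Measured compounds:
Compound 1, `Cc1cc(S(=O)(=O)NC(=O)c2ccc(N3CCN(Cc4ccccc4-c4ccc(Cl)cc4)CC3)cc2)ccc1N[C@H](CCN(C)C)CSc1ccccc1`: in an assay on isolated protein for displacement of a labelled ligand from Bcl2-associated agonist of cell death (Homo sapiens), read by fluorescence polarization (on this read-out lower numbers stand for stronger inhibition and higher numbers for weaker inhibition), compound 1 gives < 1 nM, which is a limit of the assay rather than a number.
Compound 2, `CN(C)CC[C@H](CSc1ccccc1)Nc1ccc(S(=O)(=O)NC(=O)c2ccc(N3CCN(CC4=C(c5ccc(Cl)cc5)CCC4)CC3)cc2)cc1[N+](=O)[O-]`: in this assay compound 2 gives < 1 nM, again only a limit.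
Compound 3, `CN(C)CC[C@H](CSc1ccccc1)Nc1ccc(S(=O)(=O)NC(=O)c2ccc(N3CCN(CC4=C(c5ccc(Cl)cc5)CCCCC4)CC3)cc2)cc1[N+](=O)[O-]`: in this assay compound 3 gives < 1 nM, also only a limit.

Going by the values given here, compound 1 therefore has no exact number; its result sits at the limit of < 1 nM in this assay, at which 3 of the 3 values shown sit, so nothing can be said about how it ranks against compound 2 or compound 3, and no step between measured compounds can be read off.

The unmeasured compound is compound 4, `CN(C)CC[C@H](CSc1ccccc1)Nc1ccc(S(=O)(=O)NC(=O)c2ccc(N3CCN(Cc4ccccc4-c4ccc(Cl)cc4)CC3)cc2)cc1S(=O)(=O)C(F)(F)F`. Compared with compound 1 it carries (trifluoromethyl)sulfonyl in place of methyl on an aromatic carbon; the rest of the shared core is unchanged. Among the compounds with values here, since every measured value is a limit, no measured step offers a size to lean on for this change.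

With compound 1 already at the limit, the expected step that the limit leaves unreadable from compound 1 to compound 4 is none beyond the scatter, and the result for compound 4 is expected most likely to come back again as a limit. Compound 4 is estimated at 0.5 nM, within a range from 0.1 nM to 3 nM.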

Compound 4, inhibition constant: < 1 nM
Compound 4: a limit, no number (the forecaster's own chance of this, stated with the estimate: 70%); the middle value does not contradict the limit.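

No step from compound 1 to compound 4 can be read, because both results are limits of the assay and not numbers: the limit of < 1 nM in this assay, at which 4 of the 4 values shown sit.

The compounds shown leave open whether (trifluoromethyl)sulfonyl in place of methyl on an aromatic carbon strengthens, weakens or leaves unchanged the inhibition given by compound 1, and how all four compounds rank against one another.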